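Para-Chloro Analogue of an Aryl Carbamate Selenocyanate

This account rests on a few compounds, and the source may have more. Where it says the series, first, only, none or still open, it means among the compounds named here.

Compound 2 `N#C[Se]c1ccc(NC(=O)Oc2ccccc2)cc1` is examined in a functional assay on PC-3 cells (Homo sapiens) for cytotoxicity, read by MTT assay, with a stated time of 72 h (on this read-out higher numbers stand for weaker inhibition of growth and lower numbers for stronger inhibition of growth), where compound 2 gives 37500 nM. Compound 1 `N#C[Se]c1ccc(NC(=O)Oc2ccc(F)cc2)cc1` gives 40400 nM, and compound 3 `CC(C)COC(=O)Nc1ccc([Se]C#N)cc1` gives 47300 nM, so all three numbers sit within the scatter of one another; the steps of a 1.1-fold lower number from compound 1 to compound 2 (0.03 log units; within the scatter) and a 1.3-fold higher number from compound 2 to compound 3 (0.10 log units; within the scatter) confirm this. Compound 4 `N#C[Se]c1ccc(NC(=O)Oc2ccc(Cl)cc2)cc1` differs from compound 2 by chloro in place of hydrogen on an aromatic carbon. Going by the values given here, the one step that bears on this is a 1.1-fold lower number from compound 1 to compound 2 (0.03 log units; within the scatter), where removing a halogen from the same aromatic carbon changed nothing beyond the scatter. On that basis the step of a 1.0-fold higher number from compound 2 to compound 4 (0.01 log units; within the scatter) is expected to stay within the scatter. Compound 4 is therefore estimated at 38000 nM, with a range of 20000 nM to 72000 nM.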

Compound 4, concentration for total growth inhibition: 18700 nM
Estimate against measurement, compound 4: 2.0-fold (0.31 log units) above, outside the stated range (below it).
By their numbers in this assay, from the lowest: compounds 4, 2, 1 and 3 (each within the scatter of the next, the first and the last beyond it).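

In this assay, going by these compounds alone, this position on an aromatic carbon, para to a large group, gives the first step beyond the scatter, though a modest one: a 2.2-fold lower number from compound 1 to compound 4 (0.33 log units; beyond the scatter). Against hydrogen, chloro stays within the scatter, with a 2.0-fold lower number from compound 2 to compound 4 (0.30 log units; within the scatter), so the two halogens are told apart here while neither is told apart from hydrogen. Nothing available accounts for the difference between chloro and fluoro. The compounds shown leave open how a bromo, methoxy or amine group on this carbon would read. They also leave open whether chloro would read the same at another place on this ring.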